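Cytotoxicity notes on coumarin-triazole-dithiolane series: compound 3

A few compounds are considered here, and "the series" means these few. Any claim that something is new, unique, unknown or untested is made for them only; others in the source may bear on it.

Compound 2 `COc1ccc(-c2cc3ccc(OCCCCCn4cc(CNC(=O)CCCCC5CCSS5)nn4)cc3oc2=O)cc1OC` gives 46.9% in a functional assay on PC-12 cells (Rattus norvegicus) for cytotoxicity, read by MTT assay, with stated times of 3 h and 2 h, tested at 5 uM (on this read-out lower numbers stand for a weaker effect and higher numbers for a stronger effect at the one concentration tested), and the only other measured point, compound 1 `COc1ccc(-c2cc3ccc(OCCCCCn4cc(CNC(=O)CCCCC5CCSS5)nn4)cc3oc2=O)cc1`, gives 41%; the two numbers do not separate, since a number 5.9 percentage points higher from compound 1 to compound 2 (within the scatter). Compound 3 `O=C(CCCCC1CCSS1)NCc1cn(CCCCCOc2ccc3cc(-c4ccc(Br)cc4)c(=O)oc3c2)nn1` is to be measured in this assay. Its change from compound 2 is 4-bromophenyl in place of 3,4-dimethoxyphenyl on an aromatic carbon. Among the measured compounds shown here, the one measured step bears only partly on this: it changes a single methoxy on the same ring and stays within the scatter, whereas here both methoxy groups leave and a bromine enters. For the measured compounds named here, no measured step covers the bromine. On that basis the expectation is no step beyond the scatter, with a number 5.9 percentage points lower from compound 2 to compound 3 (within the scatter) as the expected change from compound 2 to compound 3. Compound 3 is estimated at 41% in this assay, within a range from 25% to 58%, the width reflecting the untested bromine.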

Compound 3, a percentage reported as activity, at one concentration (the size of the read-out at that concentration, not a potency): 45.7%
For compound 3 the middle estimate is 4.7 percentage points below the measured one; low and high end bracket the measured number.
By their numbers in this assay, from the lowest: compounds 1, 3 and 2 (each within the scatter of the next).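

At the aromatic carbon two atoms from the ring oxygen, 4-bromophenyl in place of 3,4-dimethoxyphenyl gives a number 1.2 percentage points lower from compound 2 to compound 3 (within the scatter) in this assay and bromo in place of methoxy gives a number 4.7 percentage points higher from compound 1 to compound 3 (within the scatter) on the same read-out. The earlier step covered only one methoxy group, whereas these two show that both methoxy groups can leave and a bromine can enter without a step beyond the scatter, so none of the three aryl groups shown at this position separates from another. Nothing measured on these compounds points to a cause.

As far as these compounds go, whether an amine or a carboxylic acid on this phenyl ring would give a step beyond the scatter remains open. Among the compounds shown here, the same holds for a longer chain on the shared core, and the single tested concentration gives no potency for any compound.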